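The source may hold more compounds than are shown below. What is called first, only, known or untested is meant among the compounds shown, and "the series" means these compounds.

Measured in a functional assay on K562 cells (Homo sapiens) for cytotoxicity, read by MTT assay, with a stated time of 72 h; on this read-out higher numbers stand for weaker inhibition and lower numbers for stronger inhibition:
Compound 1 `CC(C)(C)C1=CC(=O)C=C(NCCC(=O)O)C1=O`: 67000 nM
Compound 2 `CC(C)(C)C1=CC(=O)C=C(NCC(=O)O)C1=O`: 85000 nM
Compound 3 `CC1=CCC[C@H]2[C@](C)(CC3=CC(=O)C=C(N[C@@H](CC(C)C)C(=O)O)C3=O)[C@@H](C)CC[C@]12C`: 11200 nM

Compound 2, at 85000 nM, sits at the high, weak end of these numbers, level with its closest relative. Among the measured compounds shown here, the one measured single-place step is a 1.3-fold higher number from compound 1 to compound 2 (0.10 log units; within the scatter). For the measured compounds named here, compound 3 reads clearly lower, at 11200 nM, but it differs from compound 2 in more than one place, so it shows only that lower numbers occur in this small set.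

The next step leads to compound 4 `CC(C)(C)C1=CC(=O)C=CC1=O`, which loses the whole substituent: hydrogen in place of (carboxymethyl)amino on a double-bonded ring carbon. Hydrogen now stands in place of (carboxymethyl)amino on a double-bonded ring carbon.

The measured step bears on this only loosely. It put carboxy in place of carboxymethyl and kept the amine nitrogen, whereas here the nitrogen goes too. Going by the values given here, no measured compound lacks that group, so the size of the move is a judgement. A change this large is expected to go beyond the scatter, and with compound 2 at 85000 nM, a move to a lower number seems likelier than a move higher. The estimated step is a 5.7-fold lower number from compound 2 to compound 4 (0.75 log units; beyond the scatter). Compound 4 is estimated at 15000 nM, with an expected range of 4000 nM to 50000 nM.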

Compound 4, half-maximal inhibitory concentration: 15500 nM
Compound 4: the middle estimate sits 1.0-fold (0.01 log units) below what was measured; the measured number falls inside the stated range.
By their numbers in this assay, from the lowest: compounds 3 and 4 (each within the scatter of the next); then compounds 1 and 2 (each within the scatter of the next).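

In this assay, replacing (carboxymethyl)amino with hydrogen on the double-bonded ring carbon gives a 5.5-fold lower number from compound 2 to compound 4 (0.74 log units; beyond the scatter), and replacing (2-carboxyethyl)amino in the same way gives a 4.3-fold lower number from compound 1 to compound 4 (0.64 log units; beyond the scatter), so both routes to the unsubstituted core end at a lower number, which on this read-out means stronger inhibition. Among the compounds shown here, until now, the only single-place change was a shortening of the chain, a 1.3-fold higher number from compound 1 to compound 2 (0.10 log units; within the scatter), which stayed within the scatter; these new steps show that, for these three compounds, having or lacking the whole substituent at this position matters more than that difference in chain length. No supporting data on the cause of this shift are available here.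

The two departing groups each contain both an amine nitrogen and a carboxylic acid, so these compounds cannot show whether the lower number comes from losing the nitrogen, the acid or both. A plain amino group or a simple alkylamine such as methylamino on the same ring carbon would separate those two parts, and a methyl ester of either acid would test the acid alone.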